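Compound 2 loses its (2-carboxyethyl)carbonyl group

The source may report more compounds than this note shows. Statements on the series, on what has been measured and on what is new or still open speak of the compounds shown alone.

In a functional assay on U-937 cells (Homo sapiens) for cytotoxicity, read by MTT assay, with a stated time of 72 h (on this read-out lower numbers stand for stronger inhibition and higher numbers for weaker inhibition), compound 1 (`Cc1c(C)c2c(c(C)c1OC(=O)CCC(=O)O)CCC(C)(C(=O)NC1CC(C)(C)N([O])C(C)(C)C1)O2`) gives 123000 nM, and compound 2 (`Cc1c(C)c2c(c(C)c1OC(=O)CCC(=O)O)CCC(C)(C(=O)NCC1CC(C)(C)N([O])C1(C)C)O2`) gives 24000 nM, the lower of the two numbers. Compound 3 (`Cc1c(C)c2c(c(C)c1O)CCC(C)(C(=O)NCC1CC(C)(C)N([O])C1(C)C)O2`) keeps everything on the amide-type nitrogen of compound 2 but carries hydrogen in place of (2-carboxyethyl)carbonyl on an oxygen on an aromatic ring. Going by the values given here, no measured step touches that oxygen. Among the compounds with values here, the only step available, a 5.1-fold lower number from compound 1 to compound 2 (0.71 log units; beyond the scatter), lies elsewhere in the molecule and serves merely as a yardstick for how far one change has moved the numbers here. A modest step of similar size is therefore expected in this assay, leaning tentatively toward a higher number, although the data do not settle the direction. The estimated change is a 1.9-fold higher number from compound 2 to compound 3 (0.27 log units; within the scatter). Compound 3 is expected at 45000 nM, within an estimated range of 11000 nM to 170000 nM.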

Compound 3, half-maximal inhibitory concentration: 134000 nM
Compound 3: the middle estimate sits 3.0-fold (0.47 log units) below what was measured; low and high end bracket the measured number.
By their numbers in this assay, from the lowest: compound 2; then compounds 1 and 3 (each within the scatter of the next).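

In this assay, going by these compounds alone, a 5.6-fold higher number from compound 2 to compound 3 (0.75 log units; beyond the scatter) is the first measured change at the oxygen on the aromatic ring, where ((2-carboxyethyl)carbonyl)oxy gives way to hydroxy. With everything on the amide-type nitrogen held fixed, the step shows that this substituent on the oxygen affects the number, and that its loss raises it. Like a 5.1-fold lower number from compound 1 to compound 2 (0.71 log units; beyond the scatter), which lies elsewhere in the molecule, this step is beyond the scatter, so changes at both places register in this read-out. Nothing available here explains the shift.

The compounds shown leave open whether the step depends on the carboxylic acid of the chain, which an acetyl group or a methyl ether on this oxygen could test. They also leave open whether the same change would move the number as far on compound 1.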